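Swapping the vinyl halogen in a brominated butenolide

The compounds below may be only part of what the source reports. "The series", "measured", "known", "first", "only" and "open" are said of these compounds alone.

Compounds measured so far:
compound 1, `CCC[C@@H](O)C1=C(Br)/C(=C/I)OC1=O`: 0.3 ug/mL
compound 2, `CCC[C@@H](OC(C)=O)C1=C(Br)[C@@](C)(OC)OC1=O`: 2.8 ug/mL
compound 3, `CCC[C@@H](OC(C)=O)C1=C(Br)/C(=C/I)OC1=O`: 0.2 ug/mL

In a functional assay on KB cells (Homo sapiens) for cytotoxicity (a lower number here means that less compound is needed, a higher number that more compound is needed for the effect), compound 1 gives 0.3 ug/mL, the second highest of the three numbers. Its nearest neighbour is compound 3, reached by a 1.5-fold lower number from compound 1 to compound 3 (0.18 log units; within the scatter), a step that stays within the scatter. Compound 2, which carries a saturated methoxy-bearing ring carbon in place of the iodovinyl group and an acetyl on the side-chain oxygen, gives 2.8 ug/mL in this assay, and that gap to compound 1 is beyond the scatter.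

The unmeasured compound 4 has the structure `CCC[C@@H](O)C1=C(Br)/C(=C/Cl)OC1=O`. It differs from compound 1 by chloro in place of iodo on a double-bonded chain carbon bound to a double-bonded ring carbon. Going by the values given here, no measured step changes the halogen on this double-bonded chain carbon. Among the compounds with values here, the only single-place step known, from compound 1 to compound 3, touches the side-chain oxygen and is small. What compound 2 shows is that the region around this exocyclic carbon can move the number substantially, but only when that carbon is fully rebuilt, not when one halogen replaces another. Compound 4 is therefore expected to stay close to compound 1, with the estimated step being a 1.7-fold higher number from compound 1 to compound 4 (0.22 log units; within the scatter). In this assay compound 4 is estimated at 0.5 ug/mL, within a range of 0.15 ug/mL to 2 ug/mL.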

Compound 4, concentration for half-maximal effect: 1.4 ug/mL
Compound 4: middle estimate off by 2.8-fold (0.45 log units), on the low side, and the stated range covers the measured number.
By their numbers in this assay, from the lowest: compounds 3 and 1 (each within the scatter of the next); then compounds 4 and 2 (each within the scatter of the next).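

In this assay, exchanging one halogen for another is enough to shift the number: chloro in place of iodo on a double-bonded chain carbon bound to a double-bonded ring carbon gives a 4.7-fold higher number from compound 1 to compound 4 (0.67 log units; beyond the scatter) with the rest of the structure unchanged. Going by these compounds alone, the only earlier step in one place, a 1.5-fold lower number from compound 1 to compound 3 (0.18 log units; within the scatter) on the side-chain oxygen, gave no such signal, so the iodo position is the first site in this set where a single-place change goes beyond the scatter, and the iodo group cannot be treated as freely interchangeable with chloro here. Nothing available explains this step.

With only iodo and chloro shown on this carbon, the compounds leave open whether fluoro, bromo, methyl or nitrile there would keep the number near that of compound 1 or move it further. They also leave open whether the chloro-for-iodo exchange would carry the same weight with the acetyl group on the side-chain oxygen, as in compound 3.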